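The compounds below may be only part of what the source reports. "The series", "measured", "known", "first", "only" and "open" are said of these compounds alone.

Of the compounds shown here, two sharing one core have been measured in a functional assay, read by spectrophotometry, with a stated time of 1 h; a higher number here means a weaker inhibitor, a lower number a stronger inhibitor. Compound 1 `O=c1[nH]c2ccccc2cc1/C=N/O` gives 2010000 nM, while compound 2 `N/N=C/c1cc2ccccc2[nH]c1=O` gives 365000 nM. Within the data shown here, the single recorded step, a 5.5-fold lower number from compound 1 to compound 2 (0.74 log units; beyond the scatter), concerns a change on the double-bonded nitrogen. Among the measured compounds shown here, compound 2 thus holds the lowest of the two numbers, with compound 1 as its only neighbour at a higher value.

Compound 3 `O=c1[nH]c2ccccc2cc1/C=N/Nc1ccccc1` differs from compound 2 by phenyl in place of hydrogen on an amine nitrogen. For the measured compounds named here, no measured step shows what a phenyl on this nitrogen does: the step from compound 1 to compound 2 changed a different atom and bears on it only in showing that this end of the molecule is sensitive to change. The change is therefore expected to bring a 2.4-fold lower number from compound 2 to compound 3 (0.39 log units; beyond the scatter), a guess toward a lower number carrying wide uncertainty. Compound 3 is expected at 150000 nM in this assay, within a range from 30000 nM to 800000 nM.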

Compound 3, half-maximal inhibitory concentration: 1000000 nM
The estimate for compound 3 lay 6.7-fold (0.82 log units) below the measured number; measured number outside the range, above it.
By their numbers in this assay, from the lowest: compound 2; then compounds 3 and 1 (each within the scatter of the next).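

In this assay, phenyl in place of hydrogen on the amine nitrogen brings a 2.7-fold higher number from compound 2 to compound 3 (0.44 log units; beyond the scatter) and so moves toward a weaker inhibitor. Among these compounds, this is the first reading of a substituent on this nitrogen, and it shows that a large gain in size here does not lower the number: of the two groups read at this place, hydrogen gives the lower value. Compound 2 therefore remains the one with the lowest number among the compounds shown, and nothing available here accounts for the rise seen with the phenyl.

The compounds shown leave open whether the outcome belongs to the phenyl ring itself or to any substituent on this nitrogen. A methyl, a benzyl or an acetyl group at this place could answer that, and so could a phenyl carrying a carboxylic acid.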